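Shortening the acyl group: from compound 3 to compound 4

A few compounds are considered here, and "the series" means these few. Any claim that something is new, unique, unknown or untested is made for them only; others in the source may bear on it.

Of the compounds shown here, three sharing one core have been measured in a functional assay on HCT-116 cells (Homo sapiens) for cytotoxicity, read by sulforhodamine B assay, with a stated time of 24 h; a higher number here means a weaker inhibitor, a lower number a stronger inhibitor. Compound 1 `CC(C)CCC(=O)Nc1ccn([C@H]2CC[C@H](O[C@H]3O[C@H](C)[C@@H](N(C)C)[C@H](O)[C@H]3O)[C@@H](C)O2)c(=O)n1` gives 390 nM. Compound 2 `C/C=C(\C)C(=O)Nc1ccn([C@H]2CC[C@H](O[C@H]3O[C@H](C)[C@@H](N(C)C)[C@H](O)[C@H]3O)[C@@H](C)O2)c(=O)n1` gives 6450 nM, and compound 3 `CC(C)C(=O)Nc1ccc(C(=O)Nc2ccn([C@H]3CC[C@H](O[C@H]4O[C@H](C)[C@@H](N(C)C)[C@H](O)[C@H]4O)[C@@H](C)O3)c(=O)n2)cc1` gives 6630 nM, the highest number shown, though its gap to compound 2 lies within the scatter, while the step of a 17-fold higher number from compound 1 to compound 3 (1.23 log units; beyond the scatter) is large. Compound 4 `CC(C)CC(=O)Nc1ccn([C@H]2CC[C@H](O[C@H]3O[C@H](C)[C@@H](N(C)C)[C@H](O)[C@H]3O)[C@@H](C)O2)c(=O)n1` differs from compound 3 in one place: isobutyl in place of 4-((isopropylcarbonyl)amino)phenyl on a carbonyl carbon. The step that bears on this is a 17-fold higher number from compound 1 to compound 3 (1.23 log units; beyond the scatter), a change of the opposite kind, and isobutyl is the shorter relative of isopentyl. A large fall in number is therefore expected in this assay. Compound 4 is estimated at 600 nM, within 250 nM to 2000 nM. The expected step is an 11-fold lower number from compound 3 to compound 4 (1.04 log units; beyond the scatter).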

Compound 4, half-maximal inhibitory concentration: 2140 nM
Beside the measured number, compound 4's estimate is 3.6-fold (0.55 log units) below it; measured number outside the range, above it.
By their numbers in this assay, from the lowest: compound 1; then compound 4; then compounds 2 and 3 (each within the scatter of the next).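

In this assay the small saturated isobutyl group recovers only part of the lost potency, with a 3.1-fold lower number from compound 3 to compound 4 (0.49 log units; beyond the scatter) and a 3.0-fold lower number from compound 2 to compound 4 (0.48 log units; beyond the scatter). Chain length alone still counts at this position on the carbonyl carbon: shortening isopentyl to isobutyl gives a 5.5-fold higher number from compound 1 to compound 4 (0.74 log units; beyond the scatter), so isopentyl remains the better of these two chains. Nothing measured here explains these differences. On these data alone, whether a chain longer than isopentyl, such as n-hexyl, would lower the number further remains open. So does the effect of placing an amine or a carboxylic acid at the end of the chain.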